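The source may hold more compounds than are shown below. What is called first, only, known or untested is meant among the compounds shown, and "the series" means these compounds.

Measured so far in a physicochemical assay for lipophilicity, using the shake flask method, measured as octanol-water partition, at pH 7.4; a higher number here means a more lipophilic compound, a lower number a more polar compound: compound 1 `COc1cc(/C=C/C(=O)Nc2ccccc2)ccc1OCCCN(C)C` gives 1.55; compound 2 `COc1cc(/C=C/C(=O)Nc2ccccc2)ccc1OCCCCN1CCCCC1` gives 1.61.

Compound 2 stands highest of the two numbers, with compound 1 nearest, the step of a number 0.06 log units higher from compound 1 to compound 2 (within the scatter) being within the scatter.

Compound 3 `COc1cc(/C=C/C(=O)Nc2ccccc2)ccc1O` has not been measured. It differs from compound 2 by hydrogen in place of 4-(piperidin-1-yl)butyl on an oxygen on an aromatic ring. Among the measured compounds shown here, the only measured step, a number 0.06 log units higher from compound 1 to compound 2 (within the scatter), exchanges one amine for another and does not cover removal of the whole chain, so it gives little guidance here. For compound 3 a rise beyond the scatter is expected, a number 1.19 log units higher from compound 2 to compound 3 (beyond the scatter), with a wide range: estimate 2.8, between 2.1 and 3.5.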

Compound 3, partition coefficient: 1.42
Compound 3: the middle estimate sits 1.38 log units above what was measured; the measured number lies below the stated range.
By their numbers in this assay, from the lowest: compounds 3, 1 and 2 (each within the scatter of the next).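

In this assay, hydrogen in place of 4-(piperidin-1-yl)butyl on the oxygen gives a number 0.19 log units lower from compound 2 to compound 3 (within the scatter) and hydrogen in place of 3-(dimethylamino)propyl gives a number 0.13 log units lower from compound 1 to compound 3 (within the scatter) so this read-out does not separate the free hydroxyl compound from either amine chain. The earlier compounds shown here covered only an exchange of one amine for another; the whole chain, amine included, can now go without a step beyond the scatter. Nothing available accounts for this result.

Open, from the compounds shown here alone, is whether a methyl group on the same oxygen, or a chain ending in a carboxylic acid, would also stay within the scatter of compound 3.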